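The source may hold more compounds than are shown below. What is called first, only, known or untested is meant among the compounds shown, and "the series" means these compounds.

Compound 1 (`COc1ccc(-c2oc3c(CC=C(C)C)c(OC(C)C(=O)O)cc(O)c3c(=O)c2O)cc1`) reads > 100000 nM in a functional assay on MCF7 cells (Homo sapiens) for cytotoxicity, read by MTT assay (a lower number here means a stronger inhibitor, a higher number a weaker inhibitor), which is a limit and not a number. Compound 2 (`COc1ccc(-c2oc3c(CC=C(C)C)c(OCCCC(=O)O)cc(O)c3c(=O)c2O)cc1`) also gives only a limit, > 100000 nM. Going by the values given here, the series so far shows only (the limit of > 100000 nM in this assay, at which 2 of the 2 values shown sit). Compound 3 (`CCOC(=O)COc1cc(O)c2c(=O)c(O)c(-c3ccc(OC)cc3)oc2c1CC=C(C)C`) has ethoxycarbonyl in place of 2-carboxyethyl on a saturated chain carbon bound to an oxygen on an aromatic ring. Among the compounds with values here, the one measured step, a step that the two limits leave unreadable from compound 1 to compound 2, has no readable size and gives no size to carry over. A move toward a lower number in this assay is tentatively expected, an at least 2.0-fold lower number from compound 2 to compound 3 (0.30 log units; that floor lies within the scatter), though another limit remains possible. For compound 3 the estimated value is 50000 nM, with an expected range of 12000 nM to 150000 nM.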

Compound 3, half-maximal inhibitory concentration: 27900 nM
Compound 3: middle estimate off by 1.8-fold (0.25 log units), on the high side; measured number inside the range.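

In this assay, the position on the saturated chain carbon bound to an oxygen on an aromatic ring now gives a readable response: ethoxycarbonyl in place of 2-carboxyethyl yields an at least 3.5-fold lower number from compound 2 to compound 3 (0.55 log units; beyond the scatter), and (ethoxycarbonyl)methyl in place of 1-carboxyethyl yields an at least 3.5-fold lower number from compound 1 to compound 3 (0.55 log units; beyond the scatter). Each size is only a floor. The two carboxylic acid compounds remain limits, not numbers: the limit of > 100000 nM in this assay, at which 2 of the 3 values shown sit.

The compounds shown leave open whether an amide, an amine or a longer ester chain would move the number further. With one ester alone, removal of the carboxylic acid cannot be separated from the presence of the ethyl group.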